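Furan to thiophene at the limit of the read-out

The compounds below may be only part of what the source reports. "The series", "measured", "known", "first", "only" and "open" are said of these compounds alone.

Measured in a functional assay on HepG2 cells (Homo sapiens) for antiproliferative activity, read by XTT assay, with a stated time of 72 h (on this read-out lower numbers stand for stronger inhibition and higher numbers for weaker inhibition), so far:
- compound 1 `COc1ncnc2c1c(-c1ccccc1)cn2[C@@H]1O[C@H](CO)[C@@H](O)[C@H]1O` gives > 20000 nM as a limit
- compound 2 `Nc1nc(N)c2c(-c3ccco3)cn([C@@H]3O[C@H](CO)[C@@H](O)[C@H]3O)c2n1` gives > 20000 nM as a limit

Compound 2 gives > 20000 nM in this assay as a limit of the assay and not as a number. The record for the series is the limit of > 20000 nM in this assay, at which 2 of the 2 values shown sit, and no order can be drawn from it.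

Compound 3 `Nc1nc(N)c2c(-c3cccs3)cn([C@@H]3O[C@H](CO)[C@@H](O)[C@H]3O)c2n1` carries thiophen-2-yl in place of furan-2-yl on an aromatic carbon and otherwise matches compound 2. Going by the values given here, no measured pair shows the effect of this exchange in this assay so no step beyond the scatter is expected, and any movement would be towards stronger inhibition. The estimated a number no higher from compound 2 to compound 3 (the limit leaves the size open) is expected to stay small. Compound 3 is expected near 20000 nM with an estimated range from 5000 nM to 40000 nM and may well return only a limit.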

Compound 3, half-maximal inhibitory concentration: > 20000 nM
Compound 3 gave a limit, no number; the forecaster's own chance of this, stated with the estimate: 75%; the middle value lies on the limit itself.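

No step can be read for thiophen-2-yl in place of furan-2-yl, since compound 2 and compound 3 both give a limit and not a number: the limit of > 20000 nM in this assay, at which 3 of the 3 values shown sit. The compounds shown leave open whether this exchange alters inhibition at all and how the three compounds rank.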